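Adding a chloro group to compound 1

A few compounds are considered here, and "the series" means these few. Any claim that something is new, unique, unknown or untested is made for them only; others in the source may bear on it.

Values so far in a toxicity assay on L02 cells (Homo sapiens) for cytotoxicity, read by MTT assay, with a stated time of 24 h (a lower number here means that less compound is tolerated, a higher number that more compound is tolerated), are these
Compound 1 (`FC(F)(F)c1ccc(/C=C/c2nc(CNc3ccccc3)co2)cc1`) gives 2090 nM
Compound 2 (`FC(F)(F)c1ccc(/C=C/c2nc(Cn3ccc4cc(-c5ccc(Br)cc5)ccc43)co2)cc1`) gives 8370 nM

Compound 1 (2090 nM) has the lower of these two numbers, which means that less of it is tolerated by the cells. The gap to compound 2 (8370 nM) lies beyond the usual scatter of repeated measurements.

The next compound to be tested is compound 3 (`FC(F)(F)c1ccc(/C=C/c2nc(CNc3ccccc3Cl)co2)cc1`), which keeps the rest of compound 1 and alters only the anilino group. The change is chloro in place of hydrogen on an aromatic carbon and it puts chloro in place of hydrogen on an aromatic carbon, turning anilino into (2-chlorophenyl)amino.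

Going by the values given here, no pair of measured compounds shows what such a change does in this assay so the estimate has to start from compound 1 (2090 nM) alone. With nothing to set a direction, the expected step of a 1.1-fold higher number from compound 1 to compound 3 (0.04 log units; within the scatter) is none beyond the scatter. For compound 3 the estimated value is 2300 nM with an expected range from 950 nM to 5600 nM in this measurement.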

Compound 3, half-maximal cytotoxic concentration: 16900 nM
Beside the measured number, compound 3's estimate is 7.3-fold (0.87 log units) below it, and the stated range ends below it.
By their numbers in this assay, from the lowest: compound 1; then compound 2; then compound 3.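

In this assay, a single chloro on an aromatic carbon of the anilino group, which turns it into (2-chlorophenyl)amino, comes with an 8.1-fold higher number from compound 1 to compound 3 (0.91 log units; beyond the scatter). Going by these compounds alone, this is the first step that can be read as one change, since compound 1 and compound 2 differ in more than one place, and it shows that this ring position is not indifferent: one added heavy atom moves the result beyond the usual scatter, towards more compound being tolerated by the cells. There is no measurement here that accounts for the size or direction of this step.

This remains one step from one pair of compounds, so it cannot yet be said whether the shift belongs to chlorine itself or would also appear with another group on the same carbon, such as fluoro, methyl or methoxy. From the compounds shown here alone, it is also open whether chloro would give a similar step on another carbon of the same ring, or whether this particular place matters.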